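Carbamate series: carboxy in place of isopropylcarbamoyl

A few compounds are considered here, and "the series" means these few. Any claim that something is new, unique, unknown or untested is made for them only; others in the source may bear on it.

Of the compounds shown here, two carry numbers so far. Compound 1 `CC(C)NC(=O)c1cc(-c2cccc(OC(=O)NC3CCCCC3)c2)n(-c2ccccc2)n1` gives 232 nM in an assay on isolated protein for inhibition of Fatty-acid amide hydrolase 1 (Homo sapiens), read by fluorescence, with a stated time of 30 min (a lower number here means a stronger inhibitor, a higher number a weaker inhibitor), the higher of the two values recorded. Compound 2 `NC(=O)c1cc(-c2ccc(OC(=O)NC3CCCCC3)cc2)n(-c2ccccc2)n1` gives 71 nM in this assay; it differs from compound 1 in more than one place, so its gap to compound 1 is read only as what the two numbers show, and that gap lies beyond the usual scatter.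

Compound 3 `O=C(NC1CCCCC1)Oc1cccc(-c2cc(C(=O)O)nn2-c2ccccc2)c1` has not yet been measured. Against compound 1 the counted difference is hydroxy in place of isopropylamino on a carbonyl carbon. Within the data shown here, no pair of measured compounds separated by a single change is available, so nothing in the recorded numbers tells how this particular exchange has behaved before.

Expectation for the step: a move from compound 1 to compound 3 of a 3.4-fold higher number from compound 1 to compound 3 (0.54 log units; beyond the scatter) is estimated, toward a higher number, and of a size beyond the scatter. On that basis compound 3 is expected to give about 800 nM in this assay, with an estimated range from 200 nM to 4000 nM.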

Compound 3, half-maximal inhibitory concentration: 2270 nM
Estimate against measurement, compound 3: 2.8-fold (0.45 log units) below; measured number inside the range.
By their numbers in this assay, from the lowest: compound 2; then compound 1; then compound 3.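

Notes on the carbonyl substituent: in this assay, replacing isopropylamino with hydroxy on a carbonyl carbon gives the first single-change step of the series, a 9.8-fold higher number from compound 1 to compound 3 (0.99 log units; beyond the scatter), showing that the number at this position depends on the group carried by the carbonyl. Isopropylcarbamoyl therefore gives the lower number of this pair, while carboxy moves the series toward weaker inhibition on the core of compound 1, and this rests on a single pair. The hydrogen-bond donor and acceptor counts are the same for the two exchanged groups, so those counts do not separate them, and no measurement is available that accounts for the step.

As far as these compounds go, what remains open is whether a methyl ester, a methylamino group or a longer chain on the amide nitrogen would stay near compound 1 or fall toward compound 3. Compound 2 differs from compound 1 in more than one place, so the compounds shown also leave open whether the same exchange would behave alike on the core of compound 2.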